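Compound 1 and Its Ethyl Analogue, Compound 3

The source may hold more compounds than are shown below. What is called first, only, known or untested is meant among the compounds shown, and "the series" means these compounds.

Within the data shown here, in a functional assay on M21 cells (Homo sapiens) for antiproliferative activity, read by sulforhodamine B assay, with a stated time of 48 h (on this read-out lower numbers stand for stronger inhibition and higher numbers for weaker inhibition), compound 1 `CN1CCN(c2ccc(S(=O)(=O)Oc3cccc(Cl)c3)cc2)C1=O` gives 1600 nM, the only exact number so far. For compound 2 `COc1ccc(OS(=O)(=O)c2ccc(N3CCN(C)C3=O)cc2)cc1` the assay reports > 100000 nM as a limit and not a number. Among the measured compounds shown here, the one measured step, an at least 62-fold higher number from compound 1 to compound 2 (1.79 log units; beyond the scatter), is large, but it exchanges the group on an oxygen and does not bear directly on the next change. For the measured compounds named here, compound 3 `CCN1CCN(c2ccc(S(=O)(=O)Oc3cccc(Cl)c3)cc2)C1=O` turns methyl to ethyl on the 2-oxoimidazolidin-1-yl group (methyl in place of hydrogen on a saturated chain carbon bound to an amide-type nitrogen in a ring), a place no measured step has probed. Compound 3 is therefore expected to stay close to compound 1 at 1600 nM, with no shift beyond the scatter. The expected change is a 1.1-fold higher number from compound 1 to compound 3 (0.05 log units; within the scatter). For compound 3 the estimated value is 1800 nM, within an expected range of 600 nM to 5500 nM.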

Compound 3, half-maximal inhibitory concentration: 3900 nM
Beside the measured number, compound 3's estimate is 2.2-fold (0.34 log units) below it; low and high end bracket the measured number.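

In this assay, the added methyl on a saturated chain carbon bound to an amide-type nitrogen in a ring gives a 2.4-fold higher number from compound 1 to compound 3 (0.39 log units; beyond the scatter). This place on the molecule therefore responds to a change of methyl to ethyl, although the step is modest and compound 3 keeps a measurable value. Nothing shown here bears on the reason for this shift. Going by these compounds, a single step sets no trend, so it remains open how a longer chain such as propyl would read. Also open, on these data alone, is how an amine or a carboxylic acid at the end of the chain would read.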